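The compounds below may be only part of what the source reports. "The series", "measured", "known", "first", "only" and "open" are said of these compounds alone.

Working notes on the series. Among the compounds with values here, in a functional assay on A549 cells (Homo sapiens) for inhibition, read by MTT assay and WST assay, with a stated time of 72 h, tested at 10 uM (a higher number here means more inhibition of growth at the concentration tested, a lower number less inhibition of growth), compound 2 `O=C(Nc1ccc(Oc2ccc(-c3nccs3)cc2)cc1)Nc1cccc(C(F)(F)F)c1` gives 71.5%, and compound 1 `O=C(Nc1ccc(Oc2ccc(-c3nccs3)cc2)cc1)Nc1ccc(Cl)c([N+](=O)[O-])c1` gives 77.1%; the step of a number 5.6 percentage points lower from compound 1 to compound 2 (within the scatter) lies within the scatter, so the two numbers measured so far are not separated from each other, and compound 2 sits level with compound 1 rather than apart from it.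

Compound 3 `O=C(Nc1ccc(Oc2ccc(-c3nccs3)cc2)cc1)Nc1ccc(F)c(Cl)c1` differs from compound 2 by 3-chloro-4-fluorophenyl in place of 3-(trifluoromethyl)phenyl on an amide-type nitrogen. Within the data shown here, the only measured step that bears on this is a number 5.6 percentage points lower from compound 1 to compound 2 (within the scatter), also an exchange of one aryl group for another on the same amide-type nitrogen, and it stayed within the scatter. On that basis the step to compound 3 is expected to stay within the scatter as well, with no direction beyond it, an expected step of a number 1.5 percentage points higher from compound 2 to compound 3 (within the scatter).

Compound 3 is therefore estimated at 73% in this assay, with an expected range from 60% to 84%.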

Compound 3, percent growth inhibition at one concentration: 37.3%
Estimate against measurement, compound 3: 35.7 percentage points above, and the stated range ends above it.
By their numbers in this assay, from the lowest: compound 3; then compounds 2 and 1 (each within the scatter of the next).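

In this assay the aryl group on the amide-type nitrogen proves able to move the number strongly: 3-chloro-4-fluorophenyl in place of 3-(trifluoromethyl)phenyl gives a number 34.2 percentage points lower from compound 2 to compound 3 (beyond the scatter) and in place of 4-chloro-3-nitrophenyl gives a number 39.8 percentage points lower from compound 1 to compound 3 (beyond the scatter) as well. This position therefore accepts one aryl exchange with no separable change and not another, and the chlorine shared by the groups of compound 1 and compound 3 does not by itself keep the number high. No measurement at hand offers a reason for this fall.

On these data alone, whether the fall belongs to the fluorine, to the chlorine or to the two together remains open. Also open, as far as these compounds go, is how an unsubstituted phenyl, a methoxyphenyl or an aminophenyl on this nitrogen would compare.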